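Working notes: from compound 3 to compound 4

This account rests on a few compounds, and the source may have more. Where it says the series, first, only, none or still open, it means among the compounds named here.

Within the data shown here, compound 3 `CN(C)Cc1ccc2nc(NC(=O)N/N=C/c3cn(Cc4ccc(C(C)(C)C)cc4)c4ccccc34)sc2c1` gives 810 nM in a functional assay on NCI-H460 cells (Homo sapiens) for cytotoxicity, read by MTT assay, with a stated time of 72 h (a higher number here means a weaker inhibitor, a lower number a stronger inhibitor), the lowest of the three numbers measured so far. Its nearest neighbour is compound 1 `CN(C)Cc1ccc2nc(NC(=O)N/N=C/c3cn(Cc4ccccc4Cl)c4ccccc34)sc2c1`, which gives 1600 nM; that gap is within the scatter, so no order between the two is claimed. Compound 2 `CN(C)Cc1ccc2nc(NC(=O)N/N=C/c3c[nH]c4ccccc34)sc2c1` gives 2550 nM, and the step of a 3.1-fold lower number from compound 2 to compound 3 (0.50 log units; beyond the scatter) is the only one beyond the scatter. The other steps, a 1.6-fold higher number from compound 1 to compound 2 (0.20 log units; within the scatter) and a 2.0-fold lower number from compound 1 to compound 3 (0.30 log units; within the scatter), stay within the scatter.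

Compound 4 `CN(C)Cc1ccc2nc(NC(=O)N/N=C/c3cn(Cc4ccc(Cl)c(Cl)c4)c4ccccc34)sc2c1` is not yet measured. Relative to compound 3 the change is 3,4-dichlorophenyl in place of 4-(tert-butyl)phenyl on a saturated chain carbon bound to an aromatic nitrogen. The step that bears on it most directly is a 2.0-fold lower number from compound 1 to compound 3 (0.30 log units; within the scatter), where one group on the same saturated chain carbon bound to an aromatic nitrogen was exchanged for another without a step beyond the scatter; the steps of a 3.1-fold lower number from compound 2 to compound 3 (0.50 log units; beyond the scatter) and a 1.6-fold higher number from compound 1 to compound 2 (0.20 log units; within the scatter) set a benzyl against hydrogen and so speak less to this exchange. No step beyond the scatter is therefore expected in this assay for compound 4, the estimate being a 1.2-fold higher number from compound 3 to compound 4 (0.09 log units; within the scatter). Compound 4 is expected to give about 1000 nM in this assay, within a range from 450 nM to 2300 nM.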

Compound 4, half-maximal inhibitory concentration: 1360 nM
The estimate for compound 4 lay 1.4-fold (0.13 log units) below the measured number; measured number inside the range.
By their numbers in this assay, from the lowest: compounds 3, 4, 1 and 2 (each within the scatter of the next, the first and the last beyond it).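

In this assay, 3,4-dichlorophenyl in place of 4-(tert-butyl)phenyl on a saturated chain carbon bound to an aromatic nitrogen gives a 1.7-fold higher number from compound 3 to compound 4 (0.23 log units; within the scatter), and 3,4-dichlorophenyl in place of 2-chlorophenyl at the same place gives a 1.2-fold lower number from compound 1 to compound 4 (0.07 log units; within the scatter), so this third ring pattern also yields no step beyond the scatter at this place. The step from hydrogen to 4-(tert-butyl)benzyl on the aromatic nitrogen lay beyond the scatter, but 3,4-dichlorobenzyl in place of hydrogen gives a 1.9-fold lower number from compound 2 to compound 4 (0.27 log units; within the scatter), so a step beyond the scatter from hydrogen is not shared by every benzyl group shown. No measurement at hand accounts for these numbers.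

The benzyl groups shown carry only chlorine or tert-butyl on the ring, so an amine or a carboxylic acid on that ring remains open. From the compounds shown here alone, a longer chain on the aromatic nitrogen also remains open.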